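Aryl swap on the ring nitrogen: compound 2 to compound 3

The source may hold more compounds than are shown below. What is called first, only, known or untested is meant among the compounds shown, and "the series" means these compounds.

Going by the values given here, compound 2 `CCc1ccccc1-n1nncc1CN1C(=O)C2(C(C#N)=C(N)Oc3c(N)cc4nc5ccccc5nc4c32)c2ccccc21` holds the only number in a functional assay on MCF7 cells (Homo sapiens) for antiproliferative activity, read by MTT assay, with a stated time of 48 h; on this read-out lower numbers stand for stronger inhibition and higher numbers for weaker inhibition: compound 2 gives 24600 nM. Compound 1 `Cc1ccccc1-n1nncc1CN1C(=O)C2(C(C#N)=C(N)Oc3c(N)cc4nc5ccccc5nc4c32)c2ccccc21` gives > 50000 nM, which is a limit of the assay rather than a number. The step of an at least 2.0-fold lower number from compound 1 to compound 2 (0.30 log units; that floor lies within the scatter) is methyl in place of hydrogen on a saturated chain carbon bound to an aromatic carbon; its floor rests on (the limit of > 50000 nM in this assay, at which 1 of the 2 values shown sits).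

Compound 3 `N#CC1=C(N)Oc2c(N)cc3nc4ccccc4nc3c2C12C(=O)N(Cc1cnnn1-c1ccc(F)cc1)c1ccccc12` differs from compound 2 by 4-fluorophenyl in place of 2-ethylphenyl on an aromatic nitrogen. Among the compounds with values here, no measured step exchanges this aryl group as a whole. Within the data shown here, the one step available, an at least 2.0-fold lower number from compound 1 to compound 2 (0.30 log units; that floor lies within the scatter), only lengthens a chain on that group and points to a lower number as the chain grows, but it is bounded by a limit and sits at the edge of the scatter, so it gives weak guidance here. For compound 3 a step of a 1.3-fold higher number from compound 2 to compound 3 (0.11 log units; within the scatter) is expected, toward a weaker number. Compound 3 is accordingly estimated at 32000 nM, within the range 10000 nM to 100000 nM.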

Compound 3, half-maximal inhibitory concentration: > 50000 nM
Compound 3 was reported as a limit; the forecaster's own chance of this, stated with the estimate: 35%; at least 1.5-fold (0.19 log units) between middle value and limit.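

In this assay, the exchange of the whole aryl group on the aromatic nitrogen, 4-fluorophenyl in place of 2-ethylphenyl, gives an at least 2.0-fold higher number from compound 2 to compound 3 (0.30 log units; that floor lies within the scatter), whereas the earlier step only changed the chain on that group. Going by these compounds alone, compound 3 gives > 50000 nM, which is a limit and not a number, so 2-ethylphenyl remains the only aryl group in this place that has a number. The step between compound 1 and compound 3 cannot be read, and the floor of the step from 2-ethylphenyl to 4-fluorophenyl rests on a limit: the limit of > 50000 nM in this assay, at which 2 of the 3 values shown sit.

The compounds shown do not separate the identity of the substituent on the aryl ring from its place on that ring, which a pair such as 2-fluorophenyl and 4-ethylphenyl could address. They also leave open whether a longer chain, as in 2-propylphenyl, or an amine on the ring would give a lower number than compound 2 at 24600 nM.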